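The compounds below may be only part of what the source reports. "The series", "measured", "known", "first", "only" and "open" are said of these compounds alone.

Of the compounds shown here, three sharing one core have been tested in a functional assay on PC-9 cells (Homo sapiens) for inhibition, read by MTT assay, with a stated time of 72 h; a lower number here means a stronger inhibitor, a higher number a weaker inhibitor. Compound 1 `Cc1cc(Nc2cc(-c3ccccc3)[nH]n2)n2nc(SCCc3ccccc3)nc2n1` gives 4930 nM, compound 2 `Cc1cc(Nc2cc(-c3ccccc3)[nH]n2)n2nc(SCc3ccc(F)cc3)nc2n1` gives 8110 nM, and compound 3 `Cc1cc(Nc2cc(-c3ccccc3)[nH]n2)n2nc(SCc3ccc(C(F)(F)F)cc3)nc2n1` gives 4240 nM. Among the compounds with values here, compound 2 has the highest of these three numbers, yet the steps of a 1.6-fold higher number from compound 1 to compound 2 (0.22 log units; within the scatter) and a 1.9-fold lower number from compound 2 to compound 3 (0.28 log units; within the scatter) both stay within the scatter, as does a 1.2-fold lower number from compound 1 to compound 3 (0.07 log units; within the scatter), so no compound can be called weaker or stronger. Compound 4 `CCCSc1nc2nc(C)cc(Nc3cc(-c4ccccc4)[nH]n3)n2n1` differs from compound 2 by ethyl in place of 4-fluorophenyl on a saturated chain carbon bound to a sulfur. Within the data shown here, the only step bearing on this place is a 1.6-fold higher number from compound 1 to compound 2 (0.22 log units; within the scatter), and every change tried there so far has stayed within the scatter. The step of a 1.4-fold lower number from compound 2 to compound 4 (0.13 log units; within the scatter) is therefore expected to stay within the scatter as well. Compound 4 is estimated at 6000 nM, in a range from 2500 nM to 15000 nM.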

Compound 4, half-maximal inhibitory concentration: > 50000 nM
Compound 4 gave a limit, no number (the forecaster's own chance of this, stated with the estimate: 5%); middle value at least 8.3-fold (0.92 log units) away from the limit.
By their numbers in this assay, from the lowest: compounds 3, 1 and 2 (each within the scatter of the next). At a limit, above all of these: compound 4.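

Compound 4 gives a limit of the assay, not a number: the limit of > 50000 nM in this assay, at which 1 of the 4 values shown sits. The steps of an at least 6.1-fold higher number from compound 2 to compound 4 (0.78 log units; beyond the scatter), an at least 11-fold higher number from compound 3 to compound 4 (1.07 log units; beyond the scatter) and an at least 10-fold higher number from compound 1 to compound 4 (1.00 log units; beyond the scatter) all lie beyond the scatter, so this position does respond to change. Exchanging the groups that end in an aromatic ring kept compounds 1, 2 and 3 within the scatter of one another, whereas propyl, which has no ring, gives a far higher number.

On these data alone, it remains open whether an aromatic ring itself is needed or whether a longer chain, such as hexyl, or a saturated ring, such as cyclohexylmethyl, would serve as well.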